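Pyrazolopyridine hydrazinyl ureas: methoxy to fluoro on the aryl ring

The compounds below may be only part of what the source reports. "The series", "measured", "known", "first", "only" and "open" are said of these compounds alone.

Measured so far:
compound 1, `Cn1ncc2c(-c3ccc(F)cc3)cc(NNC(=O)Nc3cc(Cl)cc(Cl)c3)nc21`, 4980 nM
compound 2, `COc1ccc(-c2cc(NNC(=O)Nc3cc(Cl)nc(OC)c3)nc3c2cnn3C)cc1`, 1980 nM

Two compounds of the series have been run in an assay on isolated protein for binding affinity to sphingosine 1-phosphate receptor 2 (Homo sapiens), read by surface plasmon resonance; a lower number here means tighter binding, a higher number weaker binding. Compound 2 gives 1980 nM, the lower of the two numbers. Its nearest neighbour is compound 1, which in this assay gives 4980 nM, a gap beyond the usual scatter. The two compounds differ in more than one place, so no single structural step can be read from their values.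

The next compound to be run is compound 3, `COc1cc(NC(=O)NNc2cc(-c3ccc(F)cc3)c3cnn(C)c3n2)cc(Cl)n1`. It differs from compound 2 in one place: fluoro in place of methoxy on an aromatic carbon; read one bond further out, 4-methoxyphenyl becomes 4-fluorophenyl. Among the compounds with values here, no measured pair shows this change on its own, so the step has no direct precedent here.

Expectation: a small step, within or just beyond the scatter, more likely toward a weaker number than a tighter one, given that only compound 1 with 4980 nM and compound 2 with 1980 nM frame the series so far. Compound 3 is estimated at 3000 nM, range 1200 nM to 7500 nM, which means an expected step of a 1.5-fold higher number from compound 2 to compound 3 (0.18 log units; within the scatter).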

Compound 3, dissociation constant: 1650 nM
The estimate for compound 3 lay 1.8-fold (0.26 log units) above the measured number; measured number inside the range.
By their numbers in this assay, from the lowest: compounds 3 and 2 (each within the scatter of the next); then compound 1.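

In this assay, 4-fluorophenyl in place of 4-methoxyphenyl gives a 1.2-fold lower number from compound 2 to compound 3 (0.08 log units; within the scatter) and so lies within the scatter: on this pair, methoxy and fluoro at this place on the aromatic ring cannot be told apart, even though methoxy brings one more heavy atom and one hydrogen-bond acceptor. Within the data shown here, compound 3 also gives the first reading of a single change on the amide-type nitrogen, where 2-chloro-6-methoxypyridin-4-yl in place of 3,5-dichlorophenyl gives a 3.0-fold lower number from compound 1 to compound 3 (0.48 log units; beyond the scatter) and so lies beyond the scatter, though the step is modest. Nothing available accounts for either step, and each rests on one pair only.

From the compounds shown here alone, it remains open whether the near-absence of a step at this aromatic carbon extends to groups of another kind, such as an amine or a carboxylic acid in place of fluoro. Also open, going by these compounds, is whether the step on the amide-type nitrogen holds with 4-methoxyphenyl, and how other groups at that nitrogen, such as an unsubstituted phenyl, would read.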